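Swapping acetyl for dimethylamino on the phenyl ring

The source may hold more compounds than are shown below. What is called first, only, known or untested is meant among the compounds shown, and "the series" means these compounds.

Compound 1 `COc1cc(C)cc(-c2c(-c3ccnc(-c4ccc(C(C)=O)cc4)c3)cnn2CC#N)c1` is one of three pyrazole-type compounds tested in a functional assay on IGROV-1 cells (Homo sapiens) for cytotoxicity, read by sulforhodamine B assay, with a stated time of 48 h, tested at 1 uM; a lower number here means a stronger effect, a higher number a weaker effect of the compound at the concentration tested. In this assay compound 1 gives 23%, the highest number of the three. Compound 3 `COc1cc(C)cc(-c2nn(CC#N)cc2-c2ccnc(-c3ccc(N(C)C)cc3)c2)c1` gives 5% and compound 2 `Cc1cc(O)cc(-c2nn(CC#N)cc2-c2ccnc(-c3ccc(Oc4ccccc4)cc3)c2)c1` gives -64%, both beyond the scatter below compound 1. Compound 4 `COc1cc(C)cc(-c2c(-c3ccnc(-c4ccc(N(C)C)cc4)c3)cnn2CC#N)c1` differs from compound 1 by a single change: dimethylamino in place of acetyl on an aromatic carbon. Compound 3 carries the same dimethylamino group on a differently arranged core, and its value sits well below that of compound 1. A downward step of moderate size is therefore expected from compound 1 to compound 4, a number 15 percentage points lower from compound 1 to compound 4 (beyond the scatter), because compound 3 gives 5%. Compound 4 is estimated at 8%, within -20% to 30%.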

Compound 4, a percentage reported as activity, at one concentration (the size of the read-out at that concentration, not a potency): 9%
The estimate for compound 4 lay 1 percentage points below the measured number, within the range that was stated.
By their numbers in this assay, from the lowest: compound 2; then compounds 3 and 4 (each within the scatter of the next); then compound 1.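

Swapping 4-acetylphenyl for 4-(dimethylamino)phenyl with the rest of the molecule unchanged gives a number 14 percentage points lower from compound 1 to compound 4 (beyond the scatter) in this assay and so a stronger effect at the concentration tested. This is the first pair shown that differs in one place, so this change can be read on its own. Nothing shown gives a measured reason for the step.

Within the data shown here, only two groups can be compared directly at this position. From the compounds shown here alone, whether a carboxylic acid or a primary amine there would move the number further remains open.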